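This account rests on a few compounds, and the source may have more. Where it says the series, first, only, none or still open, it means among the compounds named here.

Measured so far:
compound 1 `CSc1ccc(CNc2nc(SC)nc3ncccc23)cc1` in a functional assay on MCF7 cells (Homo sapiens) for cytotoxicity, read by MTT assay, with a stated time of 72 h (on this read-out higher numbers stand for lower toxicity in this test and lower numbers for higher toxicity in this test), gives 9130 nM
compound 2 `COc1ccc(CNc2nc([SeH])nc3ccccc23)cc1` in this assay gives > 100000 nM

Compound 2 stands at a limit rather than at a number: its value in this assay is only the limit reported, as the limit of > 100000 nM in this assay, at which 1 of the 2 values shown sits, shows, so no true concentration is known for it. Compound 3 `COc1ccc(CNc2nc(SC)nc3ccccc23)cc1` is not yet measured. It differs from compound 2 in one place: a group of 2 heavy atoms (1 carbon, 1 sulfur; no ring) in place of one selenium atom, on an aromatic carbon. Compound 2 and compound 3 share the rest of the structure, so the step in this assay from one to the other is carried by this exchange alone. For the measured compounds named here, compound 1 is a measured compound with a methylsulfanyl group at the same kind of site, and its value is taken as the only guide. From compound 2 to compound 3 the step is expected to be an at least 5.0-fold lower number from compound 2 to compound 3 (0.69 log units; beyond the scatter). Compound 3 is therefore estimated at 20000 nM, within a range from 5000 nM to 100000 nM.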

Compound 3, concentration lethal to 50% of the cells: > 100000 nM
Compound 3: no number, only a limit; the forecaster's own chance of this, stated with the estimate: 25%; middle value at least 5.0-fold (0.69 log units) from the limit.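

In this assay, for the compounds shown here, compound 2 and compound 3 both stand at a limit, so no step between them can be read: the limit of > 100000 nM in this assay, at which 2 of the 3 values shown sit.

The compounds shown leave open where the true values of compound 2 and compound 3 lie, and whether methylsulfanyl in place of the selenium atom changes the value at all.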